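This account rests on a few compounds, and the source may have more. Where it says the series, first, only, none or still open, it means among the compounds named here.

Measured so far in a functional assay on MGC-803 cells (Homo sapiens) for inhibition, read by MTT assay, with a stated time of 72 h; a higher number here means a weaker inhibitor, a lower number a stronger inhibitor: compound 1 `Cc1ccc(Nc2nc(SCc3cn(CC(=O)NC(=O)Nc4ccccn4)nn3)nc(-c3ccc(C(C)C)cc3)c2C#N)cc1` gives 3360 nM; compound 2 `COc1ccc(Nc2nc(SCc3cn(CC(=O)NC(=O)Nc4ccccn4)nn3)nc(-c3ccc(C)cc3)c2C#N)cc1` gives 1700 nM; compound 3 `COc1ccccc1Nc1nc(SCc2cn(CC(=O)NC(=O)Nc3ccccn3)nn2)nc(-c2ccc(C)cc2)c1C#N` gives 7960 nM.

Compound 3 stands with the highest number of the three. Its nearest neighbour is compound 1, and the largest gap is to compound 2; both gaps lie beyond the scatter.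

Compound 4 `Cc1ccc(Nc2nc(SCc3cn(CC(=O)NC(=O)Nc4ccccn4)nn3)nc(-c3ccc(C)cc3)c2C#N)cc1` is the next member. Relative to compound 3 the change is 4-methylphenyl in place of 2-methoxyphenyl on a nitrogen on an aromatic ring.

Among the compounds with values here, one measured step bears on this place: a 4.7-fold higher number from compound 2 to compound 3 (0.67 log units; beyond the scatter). That step moved the group on the same nitrogen from a 4-substituted to a 2-substituted ring and gave a higher number. The step to compound 4 runs the other way, back to a 4-substituted ring, though with methyl rather than methoxy. Compound 1 carries the same 4-methylphenyl on that nitrogen and gives 3360 nM, but it differs from compound 4 elsewhere too, so it is only a pointer. A lower number, of roughly the size of the reverse step, is expected: a 3.5-fold lower number from compound 3 to compound 4 (0.54 log units; beyond the scatter). Compound 4 is therefore estimated at 2300 nM, within 900 nM to 6000 nM.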

Compound 4, half-maximal inhibitory concentration: 9890 nM
Beside the measured number, compound 4's estimate is 4.3-fold (0.63 log units) below it; measured number outside the range, above it.
By their numbers in this assay, from the lowest: compounds 2 and 1 (each within the scatter of the next); then compounds 3 and 4 (each within the scatter of the next).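

In this assay, 4-methylphenyl on this nitrogen does not bring back the lower number seen with 4-methoxyphenyl, and the exchange for 2-methoxyphenyl lies within the scatter (a 1.2-fold higher number from compound 3 to compound 4 (0.09 log units; within the scatter)). A 4-substituted ring on the nitrogen is therefore not enough on its own, as methyl in place of methoxy on an aromatic carbon shows (a 5.8-fold higher number from compound 2 to compound 4 (0.76 log units; beyond the scatter)). Methyl in place of isopropyl on an aromatic carbon also gives a higher number (a 2.9-fold higher number from compound 1 to compound 4 (0.47 log units; beyond the scatter)), so among these compounds the smaller group does not give the lower number, and no measurement at hand accounts for either step.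

Open, from the compounds shown here alone, is how 4-hydroxyphenyl, 4-chlorophenyl or 4-aminophenyl on this nitrogen would read. Also open, going by these compounds, is whether the gap between methyl and isopropyl on an aromatic carbon persists when 4-methoxyphenyl sits on the nitrogen.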